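This account rests on a few compounds, and the source may have more. Where it says the series, first, only, none or still open, it means among the compounds named here.

Measured so far in a functional assay on BMDM cells (Mus musculus, strain C57BL/6) for inhibition, with a stated time of 2 days; on this read-out lower numbers stand for stronger inhibition and higher numbers for weaker inhibition:
- compound 1 `CCOC(=O)c1sc(NC(=O)Cn2cc(-c3cccs3)nn2)nc1C`: 20 nM
- compound 2 `Cc1csc(NC(=O)Cn2cc(-c3ccccc3Cl)nn2)n1`: 1240 nM
- compound 3 `Cc1csc(NC(=O)Cn2cc(-c3ccncc3)nn2)n1`: 100 nM

Compound 3 stands second highest of the three numbers: compound 1 gives a lower number and compound 2 a higher one, both gaps beyond the scatter. Compound 4 `CCOC(=O)c1sc(NC(=O)Cn2cc(-c3ccncc3)nn2)nc1C` is not yet measured; it differs from compound 3 by ethoxycarbonyl in place of hydrogen on an aromatic carbon. Among the compounds with values here, the only measured step, a 12-fold lower number from compound 2 to compound 3 (1.09 log units; beyond the scatter), concerns a different part of the molecule and does not bear on this change. Within the data shown here, compound 1 also carries an ethoxycarbonyl and gives 20 nM, but it differs from compound 3 in two places, so no step isolates the group. The expectation for compound 4 is therefore a moderate improvement, a 2.5-fold lower number from compound 3 to compound 4 (0.40 log units; beyond the scatter), with wide uncertainty. Compound 4 is estimated at 40 nM, between 10 nM and 160 nM.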

Compound 4, half-maximal inhibitory concentration: 120 nM
Compound 4: middle estimate off by 3.0-fold (0.48 log units), on the low side; measured number inside the range.
By their numbers in this assay, from the lowest: compound 1; then compounds 3 and 4 (each within the scatter of the next); then compound 2.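

In this assay, with pyridin-4-yl in place, ethoxycarbonyl on the aromatic carbon next to the ring sulfur gives a 1.2-fold higher number from compound 3 to compound 4 (0.08 log units; within the scatter), so the group makes no readable difference here. With ethoxycarbonyl kept, pyridin-4-yl in place of thiophen-2-yl gives a 6.0-fold higher number from compound 1 to compound 4 (0.78 log units; beyond the scatter), so the aromatic group on the other side of the molecule does make a difference. Nothing available explains either step. Still open, going by these compounds, is whether hydrogen and ethoxycarbonyl also match when thiophen-2-yl is present. A carboxylic acid or a primary amide at this carbon could also behave differently.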